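The source may hold more compounds than are shown below. What is called first, only, known or untested is meant among the compounds shown, and "the series" means these compounds.

Working notes on the series. In a functional assay on BXPC-3 cells (Homo sapiens) for cytotoxicity, read by MTT assay, with a stated time of 72 h (a lower number here means a stronger inhibitor, a higher number a weaker inhibitor), compound 1 `Nc1ccc(-c2ccc(NC3=CC(=O)c4ncncc4C3=O)cc2)cc1` gives 3500 nM. Compound 2 `COc1cccc(NC2=CC(=O)c3ncncc3C2=O)c1` gives 1800 nM, which lies within the scatter of compound 1. Compound 3 `O=C1C(Nc2cccc(B(O)O)c2)=CC(=O)c2ncncc21` gives > 10000 nM, and this is a limit of the assay, not a number.

The next compound to read is compound 4 `O=C1C(Nc2ccc(-c3ccc(F)cc3)cc2)=CC(=O)c2ncncc21`, which differs from compound 1 at one place: fluoro in place of amino on an aromatic carbon, the same change reading 4-aminophenyl to 4-fluorophenyl.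

For the measured compounds named here, no measured pair makes this exchange. Going by the values given here, the only measured step is an at least 5.5-fold higher number from compound 2 to compound 3 (0.74 log units; beyond the scatter), which also swaps one group on an aromatic carbon, though a different one and on a smaller compound. Its size is open-ended, resting on (the limit of > 10000 nM in this assay, at which 1 of the 3 values shown sits). That step shows that a single swap of this kind can carry the number beyond the scatter, but neither its size nor its direction transfers to the exchange in compound 4. The working expectation is therefore no change beyond the scatter, held with a wide margin on both sides. The expected step is a 1.2-fold lower number from compound 1 to compound 4 (0.07 log units; within the scatter). For compound 4 the estimated value is 3000 nM, with an expected range of 1000 nM to 9000 nM.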

Compound 4, half-maximal inhibitory concentration: 4400 nM
Compound 4: middle estimate off by 1.5-fold (0.17 log units), on the low side; low and high end bracket the measured number.
By their numbers in this assay, from the lowest: compounds 2, 1 and 4 (each within the scatter of the next, the first and the last beyond it). At a limit, above all of these: compound 3.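

In this assay, the exchange at this position, on an aromatic carbon para to a large group, gives a 1.3-fold higher number from compound 1 to compound 4 (0.10 log units; within the scatter) and so stays within the scatter. For the compounds shown here, this is the first reading of a swap at this position: the earlier step between compounds with a single difference concerned another group on a smaller compound, and it lay beyond the scatter. Amino carries a hydrogen-bond donor and a hydrogen-bond acceptor in the count while fluoro carries neither, yet in this one pair that difference comes with no change beyond the scatter, and nothing measured here explains the result.

Still open, going by these compounds, is whether this flat reading belongs to the pair alone or holds for the position, since a carboxylic acid, a hydroxyl group or a longer chain such as an aminoethyl group in the same place could read quite differently. Also open is whether the exchange of amino for fluoro reads the same on a compound without the 4-aminophenyl or 4-fluorophenyl group, as the compounds shown hold only this one pair.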